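This account rests on a few compounds, and the source may have more. Where it says the series, first, only, none or still open, it means among the compounds named here.

Measured so far in an assay on isolated protein for inhibition of tyrosine-protein phosphatase non-receptor type 13 (Homo sapiens), read by spectrophotometry; on this read-out higher numbers stand for weaker inhibition and lower numbers for stronger inhibition:
compound 1 `Oc1cc(-c2ccccc2)ccc1C(O)(C(F)(F)F)C(F)(F)F` gives > 500000 nM, a limit of the assay.
compound 2 `O=C(COc1ccc2cc(C(O)(C(F)(F)F)C(F)(F)F)c(O)cc2c1)Nc1ccccc1` gives > 20000 nM, a limit of the assay.
compound 3 `Oc1c(-c2ccccc2)cccc1C(O)(C(F)(F)F)C(F)(F)F` gives 449000 nM.

Of the three values shown, only compound 3 carries a plain number; the other two are limits, and compound 2 sits at the one described by the limit of > 20000 nM in this assay, at which 1 of the 3 values shown sits, while compound 1 sits at the one described by the limit of > 500000 nM in this assay, at which 1 of the 3 values shown sits. Compound 2 therefore has no measured number in this assay, and nothing in the set shows a measured inhibition stronger than its limit; its standing can only be given as that limit.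

Compound 4 `Cc1ccc(S(=O)(=O)NNC(=O)COc2ccc3cc(C(O)(C(F)(F)F)C(F)(F)F)c(O)cc3c2)cc1` differs from compound 2 in one place: ((4-methylphenyl)sulfonyl)amino in place of phenyl on an amide-type nitrogen. Going by the values given here, no pair of measured compounds differing in one place is available, so the size of this step cannot be read from the set. For the step from compound 2 to compound 4 in this assay the expectation is no change beyond the scatter, with no direction that the shown values can support, that is a step that the limit leaves unreadable from compound 2 to compound 4. Compound 4 is accordingly expected near 40000 nM, within the range 10000 nM to 200000 nM, with a real chance that this assay again reports only a limit.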

Compound 4, half-maximal inhibitory concentration: 14900 nM
For compound 4 the middle estimate is 2.7-fold (0.43 log units) above the measured one; the range from low to high includes it.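

In this assay, ((4-methylphenyl)sulfonyl)amino in place of phenyl on an amide-type nitrogen gives an at least 1.3-fold lower number from compound 2 to compound 4 (0.12 log units; that floor lies within the scatter). Going by these compounds alone, this is the first sign that this position accepts the larger group and still yields a plain number, since compound 4 gives 14900 nM. The size of the step stays bounded from one side only, and any real gain remains unproven, as compound 2 is known solely through a limit: the limit of > 20000 nM in this assay, at which 1 of the 4 values shown sits.

The compounds shown do not separate the contributions of the extra nitrogen, the sulfonyl and the 4-methyl group, and they give no cause for the step. From the compounds shown here alone, it also remains open how an unsubstituted phenylsulfonyl group, a carboxylic acid or a basic amine at the end of the same side chain would read, and whether any change on this nitrogen can move the number clearly beyond the scatter.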